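A few compounds are considered here, and "the series" means these few. Any claim that something is new, unique, unknown or untested is made for them only; others in the source may bear on it.

Working notes on the dithiocarbamate lactone series. Compound 1 `CCNC(=S)SCC1=CCOC1=O` gives 80100 nM in a functional assay on MCF7 cells (Homo sapiens) for antiproliferative activity, read by MTT assay, with a stated time of 72 h (a lower number here means a stronger inhibitor, a higher number a weaker inhibitor), the lowest of the three numbers measured. Compound 2 `CN(C)C(=S)SCC1=CC(=O)OC1` gives 159000 nM in this assay, a value that sits within the scatter of compound 1; compound 3 `O=C1C=C(CSC(=S)N2CCCC2)CO1` gives 169000 nM, a gap to compound 1 that lies just beyond the scatter. Compound 4 `O=C1OCC=C1CSC(=S)N1CCCC1` has not yet been measured. It differs from compound 1 by pyrrolidin-1-yl in place of ethylamino on a thiocarbonyl carbon. For the measured compounds named here, the one measured step that bears on this change, exchange of a dialkylamino group for pyrrolidin-1-yl on the thiocarbonyl carbon, is a 1.1-fold higher number from compound 2 to compound 3 (0.03 log units; within the scatter), which is within the scatter. Going by the values given here, the present change also removes the single hydrogen-bond donor of the ethylamino group, for which no measured step exists. On this basis the expected step is a 1.2-fold higher number from compound 1 to compound 4 (0.10 log units; within the scatter), with no change beyond the scatter anticipated, the range kept wide for the untested donor loss. Compound 4 is therefore estimated at 100000 nM in this assay, between 40000 nM and 250000 nM.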

Compound 4, half-maximal inhibitory concentration: 56400 nM
For compound 4 the middle estimate is 1.8-fold (0.25 log units) above the measured one; low and high end bracket the measured number.
By their numbers in this assay, from the lowest: compounds 4, 1, 2 and 3 (each within the scatter of the next, the first and the last beyond it).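

For the compounds shown here, this pair is the first to test a group with a hydrogen-bond donor against one without on the thiocarbonyl carbon: in this assay, pyrrolidin-1-yl in place of ethylamino gives a 1.4-fold lower number from compound 1 to compound 4 (0.15 log units; within the scatter). On the core of compound 1, the ethylamino donor is therefore not required to retain this level of antiproliferative activity, and the larger ring is tolerated, though the change combines donor loss and ring gain and the pair cannot separate them. No measurement addresses the origin of this flat step.

From the compounds shown here alone, it remains open whether any group on this carbon moves the number beyond the scatter, for example morpholin-4-yl, a piperazine or a longer chain such as hexylamino. Also open, going by these compounds, is whether ethylamino behaves the same way on the core of compound 2.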